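The compounds below may be only part of what the source reports. "The series", "measured", "known", "first", "only" and "open" are said of these compounds alone.

Compound 1 `NCCNc1cc(N2CCN(C(=O)C3(c4ccccc4)CCC3)CC2)nc2ccccc12` is one of the two measured compounds. In an ADME assay on HEp-2 cells (Homo sapiens) for cytotoxicity, read by CCK-8 assay, with a stated time of 6 days (a higher number here means that more compound is tolerated, a lower number that less compound is tolerated), compound 1 gives > 100000 nM, a limit of the assay. Compound 2 `CCC(=O)N1CCN(c2cc(NCCN)c3ccccc3n2)CC1` is the other. In this assay compound 2 gives > 100000 nM, likewise a limit. Compound 2 therefore stands only at the limit of > 100000 nM in this assay, at which 2 of the 2 values shown sit.

Compound 3 `CC(=O)N1CCN(c2cc(NCCN)c3ccccc3n2)CC1` differs from compound 2 by hydrogen in place of methyl on a saturated chain carbon bound to a carbonyl carbon, which read one bond further out is ethyl to methyl, propanoyl to acetyl. Among the measured compounds shown here, the single measured step, a step that the two limits leave unreadable from compound 1 to compound 2, cannot be sized from the two limits, so no direction is read from it. Compound 3 is expected to sit near 150000 nM, between 50000 nM and 400000 nM, a step that the limit leaves unreadable from compound 2 to compound 3 that is expected to stay within scatter.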

Compound 3, half-maximal cytotoxic concentration: > 100000 nM
Compound 3 ended at the assay's limit; the forecaster's own chance of this, stated with the estimate: 85%; the middle value lies beyond the limit too.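

Compound 3 joins compound 1 and compound 2 at a limit of this assay, so no new step among them can be read: the limit of > 100000 nM in this assay, at which 3 of the 3 values shown sit.

The compounds shown leave open where any of them truly lies beyond that limit, and whether methyl, ethyl or 1-phenylcyclobutyl on the carbonyl carbon makes any difference.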